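The source may hold more compounds than are shown below. What is called first, only, known or untested is meant among the compounds shown, and "the series" means these compounds.

Measured so far in an ADME assay on Huh-7 cells (Homo sapiens) for cytotoxicity, with a stated time of 3 days; on this read-out lower numbers stand for higher toxicity in this test and higher numbers for lower toxicity in this test:
- compound 1, `O=C(NC1CC1)c1c(NO)cc(-c2ccc(F)cc2)oc1=O`: > 20000 nM
- compound 2, `O=C(Nc1ccc(Cl)cc1)c1c(NO)cc(-c2cccs2)oc1=O`: > 20000 nM

Both values are limits of this assay, not numbers. For compound 1 the value > 20000 nM is a limit. For compound 2 the value > 20000 nM is likewise a limit, so compound 2 stands at the upper boundary of what this assay reports, and nothing in the shown data places it above or below compound 1. Evidence on this point: the limit of > 20000 nM in this assay, at which 2 of the 2 values shown sit.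

The next compound in the series is compound 3, `Nc1ccccc1NC(=O)c1c(NO)cc(-c2cccs2)oc1=O`, which has not yet been measured in this assay. Compared with compound 2 the change is 2-aminophenyl in place of 4-chlorophenyl on an amide-type nitrogen. Among the compounds with values here, no step between measured compounds exists to size this change against, and the two values on hand are both limits.

The expectation is therefore that compound 3 also sits at or beyond the limit, with no step beyond the scatter, so that a step that the limit leaves unreadable from compound 2 to compound 3 is estimated as essentially flat. Compound 3 is expected to give about 25000 nM in this assay, in a range from 12000 nM to 60000 nM, most likely reported again as a limit.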

Compound 3, half-maximal cytotoxic concentration: > 20000 nM
Compound 3 gave a limit, no number (the forecaster's own chance of this, stated with the estimate: 75%); the middle value lies beyond the limit too.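

No step can be read from compound 2 to compound 3 in this assay, as both results are limits and not numbers: the limit of > 20000 nM in this assay, at which 3 of the 3 values shown sit.

The compounds shown leave open where the half-maximal cytotoxic concentration of any of them lies, and whether 2-aminophenyl in place of 4-chlorophenyl on an amide-type nitrogen changes it at all.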